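A few compounds are considered here, and "the series" means these few. Any claim that something is new, unique, unknown or untested is made for them only; others in the source may bear on it.

Measured so far:
Compound 1 `COc1ccc(Oc2ccc3c(NCCCNCc4cc(F)ccc4OC)ccnc3c2)cc1`: 9.28
Compound 2 `COc1ccc(F)cc1CNCCCNc1ccnc2cc(C3CCCCC3)ccc12`: 9.47
Compound 3 `COc1ccc(Oc2ccc3c(NCCCNCc4cccc(OC)c4O)ccnc3c2)cc1`: 9.28

In a physicochemical assay for acid dissociation, compound 3 gives 9.28, and its nearest neighbour is compound 1: no change at the digits printed from compound 1 to compound 3 (within the scatter). Among the compounds with values here, compound 2 gives 9.47, and the only other step in the set, a number 0.19 log units higher from compound 1 to compound 2 (within the scatter), is a change at the same aromatic carbon that is altered below. All three numbers sit within the scatter of one another, so none can be ordered against the rest.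

Compound 4 `COc1cccc(CNCCCNc2ccnc3cc(-c4ccc(C(F)(F)F)cc4)ccc23)c1O` is not yet measured. It differs from compound 3 by 4-(trifluoromethyl)phenyl in place of 4-methoxyphenoxy on an aromatic carbon.

The step that bears on this is a number 0.19 log units higher from compound 1 to compound 2 (within the scatter), in which the same 4-methoxyphenoxy group left the same aromatic carbon and a group without donors or acceptors entered; that step stayed within the scatter. The exchange at the saturated chain carbon, no change at the digits printed from compound 1 to compound 3 (within the scatter), also moved nothing. No step beyond the scatter is therefore expected in this assay for compound 4.

Compound 4 is expected to give 9.3, with a range from 8.95 to 9.65. The step this estimate means is a number 0.02 log units higher from compound 3 to compound 4 (within the scatter).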

Compound 4, acid dissociation constant: 9.47
Estimate against measurement, compound 4: 0.17 log units below; measured number inside the range.
By their numbers in this assay, from the lowest: compounds 1, 3, 2 and 4 (each within the scatter of the next).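

In this assay, 4-(trifluoromethyl)phenyl in place of 4-methoxyphenoxy on the aromatic carbon gives a number 0.19 log units higher from compound 3 to compound 4 (within the scatter) and leaves the read-out without a resolved step. This position has now taken two unlike replacements of 4-methoxyphenoxy, the other being cyclohexyl in a number 0.19 log units higher from compound 1 to compound 2 (within the scatter), and the entering group here is aromatic, with 0 hydrogen-bond acceptors against the 2 that leave. The result also extends the observation to compounds carrying 2-hydroxy-3-methoxyphenyl rather than 5-fluoro-2-methoxyphenyl on the saturated chain carbon, while no supporting data are available to explain the outcome.

From the compounds shown here alone, whether a carboxylic acid or a primary amine on this aromatic carbon, or a longer chain in place of the saturated one, would give a step beyond the scatter in this assay remains open. With every step shown lying within the scatter, the compounds shown do not identify any structural change to which this read-out responds.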